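Macrocyclic lactam series: effect of the ring amide substituent

A few compounds are considered here, and "the series" means these few. Any claim that something is new, unique, unknown or untested is made for them only; others in the source may bear on it.

Three members of the series have numbers in a functional assay on HCT-116 cells (Homo sapiens) for antiproliferative activity; a lower number here means that less compound is needed, a higher number that more compound is needed for the effect. Compound 1 `Cc1c2c(n3c1CCCNC[C@H](C)Nc1cc-3ccc1C(N)=O)CC(C)(C)CC2=O` gives 93 nM. Compound 3 `Cc1c2c(n3c1CCN(C(=O)[C@@H](C)N)CC[C@H](C)Nc1cc-3ccc1C(N)=O)CC(C)(C)CC2=O` gives 710 nM. For compound 2 `CC(=O)NCCN1CC[C@H](C)Nc2cc(ccc2C(N)=O)-n2c(c(C)c3c2CC(C)(C)CC3=O)CC1=O` the assay reports only a limit, > 5000 nM, and no number. Compound 2 therefore sits at the limit of > 5000 nM in this assay, at which 1 of the 3 values shown sits, the weakest position among the three, with compound 1 and compound 3 both giving numbers under it.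

The next compound, compound 4 `Cc1c2c(n3c1CC(=O)NCC[C@H](C)Nc1cc-3ccc1C(N)=O)CC(C)(C)CC2=O`, is not yet measured. Compared with compound 2 the change is hydrogen in place of 2-acetamidoethyl on an amide-type nitrogen in a ring. The shared core stays intact; only the group on the ring amide nitrogen is exchanged for a hydrogen.

Among the compounds with values here, no measured pair in the set differs by this single change, so the size of the step is open. Within the data shown here, compound 2, carrying the 2-acetamidoethyl group, is the only member without a number, while compound 1 and compound 3, which lack such a group on the ring nitrogen, both give values. On that basis the step from compound 2 to compound 4 is expected to go toward lower numbers, an at least 6.2-fold lower number from compound 2 to compound 4 (0.79 log units; beyond the scatter), beyond the scatter. Compound 4 is estimated at 800 nM, with a range from 150 nM to 5000 nM.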

Compound 4, half-maximal effective concentration in the HCT-116 assay: 815 nM
Beside the measured number, compound 4's estimate is 1.0-fold (0.01 log units) below it; low and high end bracket the measured number.
By their numbers in the HCT-116 assay, from the lowest: compound 1; then compounds 3 and 4 (each within the scatter of the next). At a limit, above all of these: compound 2.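

Within the data shown here, in the HCT-116 assay, hydrogen in place of 2-acetamidoethyl on the amide-type nitrogen in the ring gives an at least 6.1-fold lower number from compound 2 to compound 4 (0.78 log units; beyond the scatter), the first step that can be read at this position with only this one change, though its full size stays unknown and only its lower bound is given. In a physicochemical assay for solubility (a higher number here means a more soluble compound, a lower number a less soluble compound), compound 2 gives > 100 ug/mL, a limit of the assay. In the physicochemical assay compound 4 gives > 100 ug/mL, also a limit, so the step between these two compounds cannot be read in that assay: the limit of > 100 ug/mL in the physicochemical assay, at which 2 of the 2 values shown sit.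

The compounds shown do not tell whether the step in the HCT-116 assay follows from the whole 2-acetamidoethyl group or from its terminal acetamide alone, a question that a plain ethyl or a 2-aminoethyl group on the same nitrogen would address. As far as these compounds go, how a small methyl group, a longer chain or a chain ending in a carboxylic acid at this nitrogen would fall in the HCT-116 assay also stays open.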